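Compound 3 to compound 4: an exchange of phenyl groups

A few compounds are considered here, and "the series" means these few. Any claim that something is new, unique, unknown or untested is made for them only; others in the source may bear on it.

In an ADME assay on cells (Macrophage) for cytotoxicity, read by resazurin assay, with a stated time of 48 h (a higher number here means that more compound is tolerated, a lower number that less compound is tolerated), compound 1 (`O=C(/C=C/c1ccccc1)c1ccc(OCc2cn(Cc3ccc(Br)cc3)nn2)cc1O`) gives 71700 nM and compound 2 (`Nc1nc(-c2ccc(Cl)cc2)cc(-c2ccc(OCc3cn(Cc4ccccc4)nn3)cc2O)n1`) gives 66600 nM. These two values lie within the usual scatter of each other. Compound 3 (`CCCCCCn1cc(COc2ccc(C(=O)/C=C/c3ccc(OC)cc3)c(O)c2)nn1`) has no number to set beside them, as its entry reads "not determined" (no result reported). Going by the values given here, its standing therefore remains open, and no pair of measured compounds differs in one place only.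

The change under consideration is 2-chloro-6-fluorophenyl in place of 4-methoxyphenyl on a double-bonded chain carbon bound to a double-bonded chain carbon. Compound 4 (`CCCCCCn1cc(COc2ccc(C(=O)/C=C/c3c(F)cccc3Cl)c(O)c2)nn1`) thus carries 2-chloro-6-fluorophenyl in place of 4-methoxyphenyl on a double-bonded chain carbon bound to a double-bonded chain carbon.

Among the compounds with values here, no measured step is available to show what this exchange does in this assay. The expectation is therefore for no step beyond the scatter, in either direction, relative to the two measured compounds. That expectation rests only on compound 1 at 71700 nM and compound 2 at 66600 nM, so it is weakly anchored. For compound 4, the expected value is 60000 nM, with an estimated range of 25000 nM to 140000 nM.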

Compound 4, half-maximal cytotoxic concentration: > 100000 nM
Compound 4: a limit, no number; the forecaster's own chance of this, stated with the estimate: 20%; at least 1.6-fold (0.22 log units) between middle value and limit.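

In this assay compound 4 gives > 100000 nM, which is a limit of the assay and not a number. Compound 3 has no reported value, so no step can be read between compound 3 and compound 4. As far as these compounds go, what exchanging 4-methoxyphenyl for 2-chloro-6-fluorophenyl does to tolerated concentration remains open.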